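Replacing methoxy with dimethylamino in compound 2

This account rests on a few compounds, and the source may have more. Where it says the series, first, only, none or still open, it means among the compounds named here.

In a functional assay on MT4 cells (Homo sapiens) for antiproliferative activity, read by MTT assay, with a stated time of 96 h (on this read-out higher numbers stand for weaker inhibition and lower numbers for stronger inhibition), compound 2 `COc1ccc(N2C(=O)NC3(CSC4=C3C(=O)c3ncccc3C4=O)C2=O)cc1` gives 70 nM, the lower of the two single numbers in the series. The other is from compound 1 `CCCCCc1ccc(N2C(=O)NC3(CSC4=C3C(=O)c3ncccc3C4=O)C2=O)cc1`, at 190 nM. Compound 3 `O=C1NC(=O)C2(CSC3=C2C(=O)c2ncccc2C3=O)N1` gives 130 nM; 120 nM; 130 nM (3 entries) across repeated entries. Compound 4 `CN(C)c1ccc(N2C(=O)NC3(CSC4=C3C(=O)c3ncccc3C4=O)C2=O)cc1` differs from compound 2 as follows: dimethylamino in place of methoxy on an aromatic carbon. Dimethylamino takes the place of methoxy on an aromatic carbon, para to a large group. For the measured compounds named here, the one measured step at this place, a 2.7-fold lower number from compound 1 to compound 2 (0.43 log units; beyond the scatter), was modest and came with methoxy in place of pentyl. In this assay only a small change is therefore expected, with no firm direction and the expected step, a 1.1-fold higher number from compound 2 to compound 4 (0.06 log units; within the scatter), lying within the scatter. The estimate for compound 4 is 80 nM, with an expected range of 30 nM to 210 nM.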

Compound 4, half-maximal inhibitory concentration: 15 nM
Compound 4: middle estimate off by 5.3-fold (0.73 log units), on the high side; measured number outside the range, below it.
By their numbers in this assay, from the lowest: compound 4; then compound 2; then compound 1.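

For the compounds shown here, the position tolerates more than the single earlier step showed: with dimethylamino in place of methoxy, this assay gives a 4.7-fold lower number from compound 2 to compound 4 (0.67 log units; beyond the scatter) and the step is beyond the scatter. Dimethylamino in place of pentyl gives a 13-fold lower number from compound 1 to compound 4 (1.10 log units; beyond the scatter) and is the first large step at this place. Repeated entries in the series agree closely: the several entries of compound 3 in this assay, 130 nM; 120 nM; 130 nM (3 entries)

The compounds shown leave open whether the nitrogen of dimethylamino matters or the size of the group does. A plain amine, diethylamino or an isopropyl group at the same place would separate the two.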